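Swapping (tert-butyl)carbamoyl for 3,3-dimethylbutyl

The source may report more compounds than this note shows. Statements on the series, on what has been measured and on what is new or still open speak of the compounds shown alone.

In a physicochemical assay for solubility (on this read-out lower numbers stand for lower solubility and higher numbers for higher solubility), compound 1 `CC(C)(C)CC(=O)N1CCC[C@H]1C(=O)N1CCC(NS(=O)(=O)c2cc(S(=O)(=O)c3ccccc3)ccc2C(F)(F)F)CC1` reads 25000 nM and compound 2 `CC(C)(C)NC(=O)N1CCC[C@H]1C(=O)N1CCC(NS(=O)(=O)c2cc(S(=O)(=O)c3ccccc3)ccc2C(F)(F)F)CC1` reads 50000 nM on the shared core. Among the measured compounds shown here, these two values lie within the scatter of each other, so compound 2 cannot be separated from the only other measured compound. Compound 3 `CC(C)(C)CCN1CCC[C@H]1C(=O)N1CCC(NS(=O)(=O)c2cc(S(=O)(=O)c3ccccc3)ccc2C(F)(F)F)CC1` has not yet been measured. It carries 3,3-dimethylbutyl in place of (tert-butyl)carbamoyl on an amine nitrogen in a ring and is otherwise the same as compound 2.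

For the measured compounds named here, only one measured step comes close to this change. Putting (tert-butyl)amino in place of neopentyl on a carbonyl carbon gave a 2.0-fold higher number from compound 1 to compound 2 (0.30 log units; within the scatter) and stayed within the scatter. That step exchanged groups on a carbonyl carbon, whereas the new change replaces the whole (tert-butyl)carbamoyl, so it bears on the question only in part. The data give no direction, and no step beyond the scatter is expected, though with little certainty. The expected step is a 1.4-fold lower number from compound 2 to compound 3 (0.15 log units; within the scatter) in this assay on this reading. The estimate for compound 3 is 35000 nM with 10000 nM to 100000 nM as the expected range.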

Compound 3, solubility: 12500 nM
Compound 3: the middle estimate sits 2.8-fold (0.45 log units) above what was measured; the range from low to high includes it.
By their numbers in this assay, from the lowest: compounds 3, 1 and 2 (each within the scatter of the next, the first and the last beyond it).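

In this assay, among the compounds shown here, the exchange of (tert-butyl)carbamoyl for 3,3-dimethylbutyl on an amine nitrogen in a ring gives a 4.0-fold lower number from compound 2 to compound 3 (0.60 log units; beyond the scatter) and is the first step here to pass beyond the scatter, if only modestly, so a change at this position can register on this read-out. The exchange of neopentylcarbonyl for the same 3,3-dimethylbutyl gives a 2.0-fold lower number from compound 1 to compound 3 (0.30 log units; within the scatter) and stays within the scatter, which leaves compound 1 inseparable from both compound 2 and compound 3, so that only those last two compounds stand apart. No supporting data accompany these results that could explain the step.

The three compounds do not tell whether the step from (tert-butyl)carbamoyl depends on its carbonyl, on its hydrogen-bond donor or on the group as a whole. On these data alone, it also remains open whether an amine or a carboxylic acid carried on this ring nitrogen, or a chain longer than 3,3-dimethylbutyl, would shift the number in this assay further, and in which direction.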